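A few compounds are considered here, and "the series" means these few. Any claim that something is new, unique, unknown or untested is made for them only; others in the source may bear on it.

Among the measured compounds shown here, compound 1 `COc1ccc2c(OCC[C@@H]3NC(=O)N(C)CCCC/C=C\[C@@H]4C[C@@]4(C(=O)NS(=O)(=O)N4CCC[C@H]4C#N)NC3=O)cc(-c3nc(C(C)C)cs3)nc2c1Cl` is the only member of this set with an outright number in an ADME assay on cells (Homo sapiens) for activation; on this read-out higher numbers stand for lower toxicity in this test and lower numbers for higher toxicity in this test. In this assay compound 1 gives 28300 nM. Compound 2 `COc1ccc2c(OCC[C@@H]3NC(=O)N(C)CCCC/C=C\[C@@H]4C[C@@]4(C(=O)NS(=O)(=O)C4CC4)NC3=O)cc(-c3nc(C(C)C)cs3)nc2c1F` is the other measured compound. In this assay compound 2 reaches only a limit, > 75000 nM, so no number is known for it; (the limit of > 75000 nM in this assay, at which 1 of the 2 values shown sits). For the measured compounds named here, no two measured compounds differ in a single place, so no measured step exists in this set, and the two values show only that compound 1 has a number while compound 2 has a limit. Compound 3 `COc1ccc2c(OCC[C@@H]3NC(=O)N(C)CCCC/C=C\[C@@H]4C[C@@]4(C(=O)NS(=O)(=O)C4(F)CC4)NC3=O)cc(-c3nc(C(C)C)cs3)nc2c1Cl` keeps the core of compound 1 and differs from it in one place: 1-fluorocyclopropyl in place of 2-cyanopyrrolidin-1-yl on a sulfonyl sulfur. Without a measured step to lean on, the step from compound 1 to compound 3 is expected to stay within the usual scatter, a 1.2-fold higher number from compound 1 to compound 3 (0.09 log units; within the scatter). Compound 3 is therefore estimated at 35000 nM in this assay, with a range from 15000 nM to 75000 nM.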

Compound 3, half-maximal cytotoxic concentration: 51400 nM
For compound 3 the middle estimate is 1.5-fold (0.17 log units) below the measured one, and the stated range covers the measured number.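

In this assay, among the compounds shown here, the first measured step at this place is a 1.8-fold higher number from compound 1 to compound 3 (0.26 log units; within the scatter), which gives the sulfonyl sulfur carrying the amide-type nitrogen a measured exchange that the earlier compounds did not offer. The two numbers lie within the usual scatter of each other, although 1-fluorocyclopropyl, a three-membered carbon ring, replaces 2-cyanopyrrolidin-1-yl, a five-membered ring with a nitrile and a defined stereocentre. Nothing shown gives a cause for this step.

Going by these compounds, with one step, it stays open whether other groups on this sulfur would also stay within the scatter, such as a dimethylamino group, a morpholine or a longer alkyl chain. On these data alone, it is equally open whether this exchange would give a similar step on a core other than that of compound 1.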